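The source may hold more compounds than are shown below. What is called first, only, known or untested is meant among the compounds shown, and "the series" means these compounds.

Compound 1 `C[C@]1(CS(=O)(=O)N2CC=C(C#Cc3cccc(N4CCCC4=O)c3)CC2)NC(=O)NC1=O` and compound 2 `C[C@]1(CS(=O)(=O)N2CC=C(C#Cc3cccc(N4CCCCC4=O)c3)CC2)NC(=O)NC1=O` share one core; compound 3 `O=C1CCCN1c1cnc(NCc2c(F)ccc3c2CCO3)n2cnnc12` and compound 4 `O=C1CCCCN1c1cnc(NCc2c(F)ccc3c2CCO3)n2cnnc12` share another, and the difference between the two cores is not broken down here. In a physicochemical assay for solubility, at pH 7.4 (a lower number here means a less soluble compound, a higher number a more soluble compound), compound 1 gives 94000 nM. In this assay compound 2 gives 89000 nM. The change between them is 2-oxopiperidin-1-yl in place of 2-oxopyrrolidin-1-yl on an aromatic carbon, and it made a 1.1-fold lower number from compound 1 to compound 2 (0.02 log units; within the scatter). For compound 3 the result in this assay is only a limit, < 1600 nM. That limit is the limit of < 1600 nM in this assay, at which 1 of the 3 values shown sits. Compound 4 carries the same kind of change, (2-oxopiperidin-1-yl in place of 2-oxopyrrolidin-1-yl on an aromatic carbon); here the place is on a six-membered aromatic ring with 2 nitrogen, part of a fused or bridged system of two rings, ortho and meta to a fused ring and para to a large group, rather than a ring of carbon only, meta to a large group. Because a 1.1-fold lower number from compound 1 to compound 2 (0.02 log units; within the scatter) lay within the scatter, the expected step is a step that the limit leaves unreadable from compound 3 to compound 4. Compound 4 is therefore estimated at 1000 nM, between 300 nM and 3000 nM.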

Compound 4, solubility: 351000 nM
Compound 4: the middle estimate sits 350-fold (2.55 log units) below what was measured; measured number outside the range, above it.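

In this assay, the change to 2-oxopiperidin-1-yl in place of 2-oxopyrrolidin-1-yl gave an at least 210-fold higher number from compound 3 to compound 4 (2.34 log units; beyond the scatter), while the same change on the core of compound 1 gave a 1.1-fold lower number from compound 1 to compound 2 (0.02 log units; within the scatter). The result on one core therefore did not carry over to the other in this pair of examples. The value of compound 3 is only a limit: the limit of < 1600 nM in this assay, at which 1 of the 4 values shown sits.

These two pairs do not show which feature of the cores separates the two outcomes, or what the change would do on a third core. The compounds shown also leave open how 2-oxoazepan-1-yl or an open-chain acetamide would read at the same place on either core.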